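A few compounds are considered here, and "the series" means these few. Any claim that something is new, unique, unknown or untested is made for them only; others in the source may bear on it.

Measured compounds:
- compound 1, `Nc1ccccc1S(=O)(=O)N1CC(n2cnc3c(Cl)nc(Cl)nc32)OCc2ccccc21`: 820 nM
- compound 2, `O=[N+]([O-])c1ccc(S(=O)(=O)N2C[C@@H](n3cnc4c(Cl)nc(Cl)nc43)OCc3ccccc32)cc1`: 100 nM

In a functional assay on MCF7 cells (Homo sapiens) for cytotoxicity, read by sulforhodamine B assay, with a stated time of 3 days (a lower number here means a stronger inhibitor, a higher number a weaker inhibitor), compound 1 gives 820 nM, the highest of the two numbers available; compound 2, which gives 100 nM, sits well below it, and that gap lies beyond the usual scatter. For the measured compounds named here, compound 2 also carries a nitro group on the phenyl ring of its sulfonamide, though it differs from compound 1 in more than one place, so no single step between them can be read.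

Compound 3, `O=[N+]([O-])c1ccccc1S(=O)(=O)N1CC(n2cnc3c(Cl)nc(Cl)nc32)OCc2ccccc21`, is not yet measured. It differs from compound 1 in one place only: nitro in place of amino on an aromatic carbon. The shared core, the sulfonamide and the ring that bears the group are all unchanged.

Going by the values given here, with no measured single step of this kind to lean on, the expectation rests on the fact that compound 2, the only other compound here and the one bearing a nitro group, gives 100 nM in this assay. On that basis compound 3 is expected to move toward a lower number than compound 1, a step estimated at a 2.7-fold lower number from compound 1 to compound 3 (0.44 log units; beyond the scatter), most likely modest and only a little beyond the scatter. The estimate for compound 3 in this assay is 300 nM, with a range from 100 nM to 900 nM.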

Compound 3, half-maximal inhibitory concentration: 383 nM
The estimate for compound 3 lay 1.3-fold (0.11 log units) below the measured number; the measured number falls inside the stated range.
By their numbers in this assay, from the lowest: compound 2; then compound 3; then compound 1.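

In this assay, for the compounds shown here, the change from 2-aminophenyl to 2-nitrophenyl gives the first step in this set that can be read at a single place (a 2.1-fold lower number from compound 1 to compound 3 (0.33 log units; beyond the scatter)). It shows that the group on this aromatic carbon, ortho to a large group, affects the read-out, and that nitro there gives a modestly lower number than amino. The step also replaces a group that has a hydrogen-bond donor with a larger one that has none, and the number does not rise, but nothing shown explains why the number moves.

On these data alone, compound 2 differs from the other two compounds in more than one place, so steps involving it cannot be read, and whether moving the nitro group to another carbon of the ring changes the number remains open. As far as these compounds go, it also remains open how a carboxylic acid, a methyl group or a plain hydrogen on the same carbon would compare with amino and nitro, and so whether this single step reflects a wider trend.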